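From bromo to fluoro on a shared core

The source may report more compounds than this note shows. Statements on the series, on what has been measured and on what is new or still open speak of the compounds shown alone.

Measured so far:
- compound 1, `Clc1ccc(OCC2=NCCO2)cc1`: 12% in a toxicity assay on the whole organism with Rattus norvegicus as the target, at a dose of 400 mg/kg by the oral route; on this read-out higher numbers stand for a stronger effect at the one dose given and lower numbers for a weaker effect
- compound 2, `Brc1ccc(OCC2=NCCO2)cc1`: 15% in this assay

Of the compounds shown here, two have been tested, and they differ only in the halogen on the aromatic carbon. Within the data shown here, on the numbers available, compound 2 has the higher figure; its only neighbour is compound 1, and the step of a number 3 percentage points higher from compound 1 to compound 2 (within the scatter) lies within the scatter, so the two results cannot be told apart.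

Compound 3, `Fc1ccc(OCC2=NCCO2)cc1`, differs from compound 2 by fluoro in place of bromo on an aromatic carbon. Among the measured compounds shown here, the one measured step that bears on this change is the halogen exchange from compound 1 to compound 2, also at the same aromatic carbon, and it amounted to a number 3 percentage points higher from compound 1 to compound 2 (within the scatter). A second halogen exchange at that position is therefore expected to move this assay by no more than the scatter, in no clear direction.

Compound 3 is accordingly estimated at 13%, with a range from 3% to 25%. The expected step is a number 2 percentage points lower from compound 2 to compound 3 (within the scatter), within the scatter.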

Compound 3, a percentage reported as activity, at one dose (the size of the read-out at that dose, not a potency): 75%
For compound 3 the middle estimate is 62 percentage points below the measured one; the measured number lies above the stated range.
By their numbers in this assay, from the lowest: compounds 1 and 2 (each within the scatter of the next); then compound 3.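

In this assay the aromatic carbon para to a group of 7 heavy atoms proves far more sensitive to the choice of halogen than the earlier pair suggested: fluoro in place of bromo gives a number 60 percentage points higher from compound 2 to compound 3 (beyond the scatter) and fluoro in place of chloro gives a number 63 percentage points higher from compound 1 to compound 3 (beyond the scatter) on the same shared core. The halogens at this carbon are therefore not interchangeable, since the exchange of chloro for bromo gave only a number 3 percentage points higher from compound 1 to compound 2 (within the scatter) while fluoro alone stands clearly apart from both, and this holds only for these three compounds. Nothing available here accounts for why fluoro separates from the other two halogens.

Going by these compounds, it remains open whether a methyl, methoxy or trifluoromethyl group, or plain hydrogen, at this aromatic carbon would give a figure near that of compound 3 or near those of compound 1 and compound 2. Also open, on these data alone, is whether the large fluoro step would persist at other doses, or on a core carrying a longer chain or an amine in place of the present group.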